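A few compounds are considered here, and "the series" means these few. Any claim that something is new, unique, unknown or untested is made for them only; others in the source may bear on it.

Going by the values given here, in an ADME assay on HEK-293T cells (Homo sapiens) for cytotoxicity, read by resazurin assay, with a stated time of 72 h (a higher number here means that more compound is needed for the effect, a lower number that less compound is needed), only two compounds have numbers so far. Compound 1 (`OCCCCCCCCCCCCCc1cccnc1`) reads 204000 nM and compound 2 (`COc1ccc(C[n+]2cccc(CCCCCCCCCCCCCO)c2)cc1`) reads 21000 nM on the same scale. Compound 2 therefore holds the lower number of the two, so less of it is needed for the effect, and the gap lies beyond the usual scatter. The change from compound 2 to compound 3 (`COc1ccc(C[n+]2cccc(CCCCCCCCCCCCCI)c2)cc1`) is iodo in place of hydroxy on a saturated chain carbon, ten or more bonds along the chain from an aromatic carbon and puts iodo in place of hydroxy on a saturated chain carbon, ten or more bonds along the chain from an aromatic carbon. Among the compounds with values here, no measured pair shows this swap, so the forecast is loose. The expected change is a 2.1-fold lower number from compound 2 to compound 3 (0.32 log units; beyond the scatter) as a modest move towards a lower number, only just beyond the scatter. Compound 3 is estimated in this assay at 10000 nM with an expected range from 2500 nM to 40000 nM for now.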

Compound 3, half-maximal effective concentration: 41000 nM
Estimate against measurement, compound 3: 4.1-fold (0.61 log units) below, and the stated range ends below it.
By their numbers in this assay, from the lowest: compounds 2 and 3 (each within the scatter of the next); then compound 1.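

Going by these compounds alone, for the first time, this swap can be read directly: iodo in place of hydroxy, on a saturated chain carbon, gives a 2.0-fold higher number from compound 2 to compound 3 (0.29 log units; within the scatter) in this assay. At this position, then, the two groups cannot be told apart in this cytotoxicity read-out, even though the hydrogen-bond donor and acceptor counted on hydroxy are gone and iodo brings neither. No available evidence explains this outcome.

As far as these compounds go, whether the same holds for an amine or a carboxylic acid at this chain end, or for a shorter or longer chain, remains open. This single pair also cannot show whether the swap would behave alike on the uncharged core of compound 1.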